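Removing the cyclopentyl group from compound 2

The source may report more compounds than this note shows. Statements on the series, on what has been measured and on what is new or still open speak of the compounds shown alone.

In an ADME assay on liver (Homo sapiens) for metabolic stability, read by LC-MS, using microsomes and NADPH (a higher number here means that more of the compound is left, a lower number that less of the compound is left), compound 1 `CCCN(Cc1ccc(OCCN2C(=O)CCC2=O)c(C)c1)C(CC(=O)O)c1ccc(Cl)cc1` gives 85%, while compound 2 `Cc1cc(CN(CC2CCCC2)C(CC(=O)O)c2ccc(Cl)cc2)ccc1OCCN1C(=O)CCC1=O` gives 65%, the lower of the two numbers. Among the compounds with values here, compound 2 therefore leaves the more room for a rise among the compounds measured so far.

The next compound is compound 3 `Cc1cc(CN(CCC(F)(F)F)C(CC(=O)O)c2ccc(Cl)cc2)ccc1OCCN1C(=O)CCC1=O`. Its structure departs from that of compound 2 in one place: 2,2,2-trifluoroethyl in place of cyclopentyl on a saturated chain carbon bound to an amine nitrogen. Thus 2,2,2-trifluoroethyl stands in place of cyclopentyl on a saturated chain carbon bound to an amine nitrogen.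

Within the data shown here, only one measured step bears on this change: a number 20 percentage points lower from compound 1 to compound 2 (beyond the scatter). That modest step, beyond the scatter, came with the entry of the cyclopentyl group, which compound 3 no longer carries. Among the measured compounds shown here, no measured compound shows what the 2,2,2-trifluoroethyl group does, so this single comparison is a thin guide. A modest rise of similar size is nevertheless expected in this assay. The expected change is a number 13 percentage points higher from compound 2 to compound 3 (beyond the scatter). The estimate for compound 3 is 78%, with an expected range from 62% to 93%.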

Compound 3, percent of the compound remaining: 81%
Compound 3: middle estimate off by 3 percentage points, on the low side; the measured number falls inside the stated range.
By their numbers in this assay, from the lowest: compound 2; then compounds 3 and 1 (each within the scatter of the next).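

The trifluoroethyl result shows that the drop seen with the cyclopentyl group does not follow from the heavy-atom count of the group at this place: 2,2,2-trifluoroethyl and cyclopentyl count the same, yet this assay gives a number 16 percentage points higher from compound 2 to compound 3 (beyond the scatter) for the exchange. Fluorine on the chain is also tolerated here, since trifluoromethyl in place of methyl gives a number 4 percentage points lower from compound 1 to compound 3 (within the scatter) and thus no difference that can be told from the scatter. Among these compounds, the open chains of compound 1 and compound 3 stand together and the ring-bearing compound 2 stands apart, though no measurement shown gives a reason for these steps.

The compounds leave open whether the ring itself accounts for the lower number, as a cyclopropyl or cyclobutyl group, or an open butyl or pentyl chain, in place of cyclopentyl could test. They also leave open whether fluorine on the cyclopentyl ring, or a tetrahydropyranyl ring in its place, would bring the number back toward that of the open chains.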